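Capping the tetrazole: methyl for hydrogen on ring nitrogen

The compounds below may be only part of what the source reports. "The series", "measured", "known", "first", "only" and "open" are said of these compounds alone.

Compound 1 `FC(F)(F)c1cc(COC[C@@H](NCc2nc[nH]n2)c2ccccc2)cc(C(F)(F)F)c1`: 5 nM
Compound 2 `CN(Cc1nn[nH]n1)[C@H](COCc1cc(C(F)(F)F)cc(C(F)(F)F)c1)c1ccccc1`: 70 nM

Of the compounds shown here, two have been measured in an assay on CHO cells for displacement of a labelled ligand from Substance-P receptor (Homo sapiens); a higher number here means a weaker inhibitor, a lower number a stronger inhibitor. Going by the values given here, compound 1 gives 5 nM, while compound 2 gives 70 nM, the higher of the two numbers; the only measured step, a 14-fold higher number from compound 1 to compound 2 (1.15 log units; beyond the scatter), was a clear loss. Compound 3 `CN(Cc1nnn(C)n1)[C@H](COCc1cc(C(F)(F)F)cc(C(F)(F)F)c1)c1ccccc1` differs from compound 2 by methyl in place of hydrogen on an aromatic nitrogen. Among the compounds with values here, no measured step touches this position: the step from compound 1 to compound 2 changed both the azole ring and the amine substituent at once, so it says nothing direct about capping a ring nitrogen. With no guide in the data, the step of a 2.1-fold higher number from compound 2 to compound 3 (0.33 log units; beyond the scatter) is expected to be modest, with a slight lean toward a weaker binder. Compound 3 is therefore estimated at 150 nM in this assay, with a range of 40 nM to 600 nM.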

Compound 3, half-maximal inhibitory concentration: 16 nM
Compound 3: middle estimate off by 9.4-fold (0.97 log units), on the high side; measured number below the stated range.
By their numbers in this assay, from the lowest: compound 1; then compound 3; then compound 2.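

In this assay, methyl on the ring nitrogen is not just tolerated but gives a gain: a 4.4-fold lower number from compound 2 to compound 3 (0.64 log units; beyond the scatter). So the hydrogen on that nitrogen of the 2H-tetrazol-5-yl group is not required for binding in this series, and part of the earlier loss is regained, though not all of it: a 3.2-fold higher number from compound 1 to compound 3 (0.51 log units; beyond the scatter), with methyl((2-methyl-2H-tetrazol-5-yl)methyl)amino in place of ((1H-1,2,4-triazol-3-yl)methyl)amino. Nothing in hand gives a reason for this gain.

An ethyl group or a longer chain on the same ring nitrogen could show whether the gain is particular to methyl. The remaining gap to compound 1 also stays unassigned, since the ring and the methyl on the chain nitrogen change together there.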